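The compounds below may be only part of what the source reports. "The series", "measured", "known", "first", "only" and "open" are said of these compounds alone.

Measured so far:
Compound 1, `CCCCCc1ccc2nc(N)sc2c1` — in a functional assay on the whole organism with Rattus norvegicus as the target (on this read-out higher numbers stand for an effect only at larger amounts of compound and lower numbers for an effect already at smaller amounts), compound 1 gives 7.5 mg/kg.
Compound 2, `CCCCCCCc1ccc2nc(N)sc2c1` — in this assay compound 2 reaches only a limit of the assay, > 10 mg/kg, not a number.
Compound 3, `N#CCn1c(=N)sc2cc(OC(F)(F)F)ccc21` — in this assay compound 3 gives 3.5 mg/kg.

Of the two numbers available, compound 3 gives the lower one, and compound 1 gives a higher number; that gap lies beyond the usual scatter. Within the data shown here, the single measured step, an at least 1.3-fold higher number from compound 1 to compound 2 (0.12 log units; that floor lies within the scatter), shows that lengthening the chain on the core of compound 1 did not lower the number; its floor sits within the scatter, and the step ends at a limit (the limit of > 10 mg/kg in this assay, at which 1 of the 3 values shown sits).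

The compound not yet measured is compound 4, `N=c1sc2cc(OC(F)(F)F)ccc2n1CCS`. It differs from compound 3 by sulfanylmethyl in place of cyano on a saturated chain carbon bound to an aromatic nitrogen. Among the measured compounds shown here, no measured step touches this part of the structure, and the only measured step concerns a chain on a different core, so it gives little guidance here. For the measured compounds named here, with no comparable step to lean on, the expected step of a 1.1-fold higher number from compound 3 to compound 4 (0.06 log units; within the scatter) is none beyond the scatter. Compound 4 is therefore estimated to give 4 mg/kg in this assay, within a range of 2 mg/kg to 9 mg/kg.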

Compound 4, dose for half-maximal effect: 2 mg/kg
Compound 4: middle estimate off by 2.0-fold (0.30 log units), on the high side, within the range that was stated.
By their numbers in this assay, from the lowest: compounds 4 and 3 (each within the scatter of the next); then compound 1. At a limit, above all of these: compound 2.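

In this assay the change on a saturated chain carbon bound to an aromatic nitrogen gives a 1.8-fold lower number from compound 3 to compound 4 (0.24 log units; within the scatter) and so stays within what repeated measurements of one compound would show. Among these compounds, this is the first measured change at this place, and it shows that, for this pair, the read-out in the whole animal does not depend on keeping cyano: sulfanylmethyl, which has no triple bond and brings a hydrogen-bond donor, gives a value that cannot be told apart from that of the nitrile. Nothing measured here explains why these two different groups end up so close in this read-out.

Among the compounds shown here, only this one swap has been seen at this place, so it remains open whether an amine, a carboxylic acid or a longer chain on the same carbon would also stay within the scatter or would move the number clearly up or down. Going by these compounds, it is also open whether sulfanylmethyl would behave the same way on the core of compound 1, which carries a different group on its ring and a free amine.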